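The compounds below may be only part of what the source reports. "The series", "measured", "known", "first", "only" and "open" are said of these compounds alone.

Within the data shown here, in a functional assay on NCI-H460 cells (Homo sapiens) for inhibition, read by MTT assay, with a stated time of 24 h, tested at 100 ug/mL (on this read-out higher numbers stand for more inhibition of growth at the one concentration tested and lower numbers for less inhibition of growth), two compounds have numbers so far. Compound 1 `O=C(CCCCC(S)CCS)Nc1ccc(Br)cn1` gives 55.9%, and compound 2 `CC(=O)SCCC(CCCCC(=O)Nc1ccccc1)SC(C)=O` gives 44.8%. Compound 2 is therefore the lower of the two, and its gap to compound 1 lies beyond the usual scatter of such measurements. These two compounds differ in more than one place, so that gap cannot be tied to any single change.

The next compound, compound 3 `CC(=O)SCCC(CCCCC(=O)Nc1ccc(Cl)cc1)SC(C)=O`, differs from compound 2 in one place only: chloro in place of hydrogen on an aromatic carbon. Put simply, the phenyl of compound 2 becomes 4-chlorophenyl in compound 3.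

Among the measured compounds shown here, no measured pair shows this change on its own, so the data offer no direct guide to its size. For the measured compounds named here, the only anchor is compound 2 at 44.8%, and the swap touches one position while the rest of the molecule stays the same. A small rise that stays within the scatter is expected, as the estimated a number 4.2 percentage points higher from compound 2 to compound 3 (within the scatter) shows. Compound 3 is estimated at 49%, with an expected range from 36% to 62%.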

Compound 3, percent growth inhibition at one concentration: 47.3%
For compound 3 the middle estimate is 1.7 percentage points above the measured one; the range from low to high includes it.
By their numbers in this assay, from the lowest: compounds 2, 3 and 1 (each within the scatter of the next, the first and the last beyond it).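

Among these compounds, this is the first pair here that differs in one place only, so it gives the first direct look at this position, an aromatic carbon para to a large group. In this assay, chloro in place of hydrogen at this position gives a number 2.5 percentage points higher from compound 2 to compound 3 (within the scatter) and so, taken alone, this one added chlorine atom does not separate the two compounds on this read-out. No supporting measurement is available that could explain this result.

From the compounds shown here alone, whether the number would hold with a different group at the same carbon, such as methoxy, an amine or a carboxylic acid, remains open, as does the effect of moving chloro to another carbon of the same ring. Also open is which of the several differences between compound 2 and compound 1 accounts for the gap between those two, since no series of single changes yet connects them.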